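The source may hold more compounds than are shown below. What is called first, only, known or untested is meant among the compounds shown, and "the series" means these compounds.

Compound 1 `COc1ccc(/C=C/S(=O)(=O)Cc2ccc(OC)cc2)cc1`: > 20000 nM
Compound 2 `COc1cc(OC)c(/C=C/S(=O)(=O)Cc2ccc(Cl)cc2)c(OC)c1`: 10000 nM

Of the compounds shown here, two have been measured in a functional assay on BT-20 cells (Homo sapiens) for antiproliferative activity, read by trypan blue exclusion; a lower number here means a stronger inhibitor, a higher number a weaker inhibitor. For compound 1 the value > 20000 nM is a limit of the assay rather than a number; it sits at the limit of > 20000 nM in this assay, at which 1 of the 2 values shown sits. Compound 2 gives 10000 nM in this assay, a number rather than a limit. Compound 1 thus stands at the weak end of what this assay can report, and whether it lies close to compound 2 or far beyond it cannot be read from these two values.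

Compound 3 `COc1ccc(CS(=O)(=O)/C=C/c2ccc(F)cc2)cc1` has not yet been measured. It differs from compound 1 in one place: fluoro in place of methoxy on an aromatic carbon, a fluoro in place of methoxy on an aromatic carbon, para to a large group. Going by the values given here, no step between two measured compounds covers this change, so nothing here shows how large an effect it has. The expectation for compound 3 is a value close to the limit, with the step of a number no higher from compound 1 to compound 3 (the limit leaves the size open) expected to stay within the scatter. Compound 3 is estimated at 20000 nM, in a range from 8000 nM to 50000 nM.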

Compound 3, half-maximal inhibitory concentration: 1500 nM
For compound 3 the middle estimate is 13-fold (1.12 log units) above the measured one, and the stated range ends above it.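

Placing fluoro in place of methoxy on this aromatic carbon, para to a large group, gives an at least 13-fold lower number from compound 1 to compound 3 (1.12 log units; beyond the scatter) in this assay. This shows that the position is not indifferent: a single change here, with one heavy atom entering where two leave, moves the antiproliferative read-out by far more than repeat measurements would. Compound 1 gives > 20000 nM, which is a limit of the assay and not a number, so only the smallest possible size of this step is known, and the real step may be larger: the limit of > 20000 nM in this assay, at which 1 of the 3 values shown sits.

With only this one change at this carbon, the compounds shown do not separate what fluoro itself contributes from what is lost with the methoxy, a question that a plain hydrogen, a bromo or a nitrile at the same carbon would address. Also open, as far as these compounds go, is how an amine or a carboxylic acid would read at this carbon, and whether the same swap would matter at the remaining methoxy, which compound 1 and compound 3 share.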